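The source may hold more compounds than are shown below. What is called first, only, known or untested is meant among the compounds shown, and "the series" means these compounds.

Measured compounds:
- compound 1 `[SeH]c1nc([SeH])c2ccccc2n1`: 490 nM
- compound 3 `[SeH]c1nc([SeH])c2cccnc2n1`: 710 nM
- compound 2 `Nc1nc([SeH])nc2ncccc12`: 5200 nM

In an ADME assay on 184B5 cells (Homo sapiens) for cytotoxicity, read by MTT assay, with a stated time of 72 h (a higher number here means a weaker inhibitor of growth, a lower number a stronger inhibitor of growth), compound 1 gives 490 nM and compound 3 gives 710 nM; the two lie within the scatter of each other. The difference between the two cores is not broken down here. Compound 2 gives 5200 nM, and the change from compound 3 to compound 2, (one nitrogen atom in place of one selenium atom, on an aromatic carbon), brought a 7.3-fold higher number from compound 3 to compound 2 (0.86 log units; beyond the scatter).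

Compound 4 `Nc1nc([SeH])nc2ccccc12` is not yet measured. It arises from compound 1 by one nitrogen atom in place of one selenium atom, on an aromatic carbon, the same change as from compound 3 to compound 2, at the same place. The step from compound 1 to compound 4 in this assay is expected to be about a 7.1-fold higher number from compound 1 to compound 4 (0.85 log units; beyond the scatter), resting on the step from compound 3 to compound 2, a 7.3-fold higher number from compound 3 to compound 2 (0.86 log units; beyond the scatter). Compound 4 is therefore estimated at 3500 nM, between 1200 nM and 10000 nM.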

Compound 4, concentration for 50% growth inhibition: 690 nM
For compound 4 the middle estimate is 5.1-fold (0.71 log units) above the measured one; the whole stated range lies above it.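

In this assay, amino in place of selenium on the core of compound 1 gives a 1.4-fold higher number from compound 1 to compound 4 (0.15 log units; within the scatter), so the step seen on the other core does not carry over in size: the same change on two cores in this assay, a 7.3-fold higher number (0.86 log units; beyond the scatter) from compound 3 to compound 2 and a 1.4-fold higher number (0.15 log units; within the scatter) from compound 1 to compound 4, 5.2-fold (0.72 log units) apart, beyond the scatter of two such steps

The size of this change therefore depends on the core across these two pairs, and a step read on one core is no safe estimate for the other. Two pairs do not show why the cores differ, or which step would be more usual across further cores.

Still open, on these data alone, is how a thiol or a methylamino group would behave at this place on either core. Also open, as far as these compounds go, is whether the same change at the other selenium-bearing carbon would depend on the core.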